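Trifluoromethoxy for isopropyl on a sulfonyl aryl ring

The source may report more compounds than this note shows. Statements on the series, on what has been measured and on what is new or still open speak of the compounds shown alone.

Three compounds sharing the core of compound 1 `CC1CCN(C2CCN(S(=O)(=O)c3ccc(-c4ccccc4F)cc3)CC2)CC1` have been tested in a functional assay on DLD-1 cells (Homo sapiens) for antiproliferative activity, read by CellTiter-Glo, with a stated time of 72 h; a lower number here means a stronger inhibitor, a higher number a weaker inhibitor. Compound 1 gives 5 nM. Compound 2 `CC1CCN(C2CCN(S(=O)(=O)c3ccc(OCc4ccccc4)cc3)CC2)CC1` gives 385 nM, and compound 3 `CC1CCN(C2CCN(S(=O)(=O)c3ccc(C(C)C)cc3)CC2)CC1` gives 685 nM, the highest of the three numbers. The step of a 140-fold higher number from compound 1 to compound 3 (2.14 log units; beyond the scatter) is large, as is a 77-fold higher number from compound 1 to compound 2 (1.89 log units; beyond the scatter), whereas a 1.8-fold higher number from compound 2 to compound 3 (0.25 log units; within the scatter) stays within the scatter.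

Compound 4 `CC1CCN(C2CCN(S(=O)(=O)c3ccc(OC(F)(F)F)cc3)CC2)CC1` differs from compound 3 by trifluoromethoxy in place of isopropyl on an aromatic carbon. Both measured steps involving compound 3 bear on this change: replacing the 2-fluorophenyl with an acyclic group cost a great deal, while swapping between two non-aryl groups, benzyloxy and isopropyl, changed nothing beyond the scatter. Trifluoromethoxy is again an acyclic group, so the expected step in this assay from compound 3 is small, in either direction, with no change beyond the scatter as the estimate: a 1.1-fold lower number from compound 3 to compound 4 (0.06 log units; within the scatter). Compound 4 is thus estimated at 600 nM, with a range from 200 nM to 2000 nM.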

Compound 4, half-maximal inhibitory concentration: 16 nM
Compound 4: the middle estimate sits 38-fold (1.57 log units) above what was measured, outside the stated range (below it).
By their numbers in this assay, from the lowest: compound 1; then compound 4; then compounds 2 and 3 (each within the scatter of the next).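

In this assay, among these compounds, the position on the aromatic carbon turns out to be far more sensitive than the earlier compounds suggested, and a group with no ring can come close to the 2-fluorophenyl of compound 1: the change gives a 43-fold lower number from compound 3 to compound 4 (1.63 log units; beyond the scatter), yet a modest gap remains in a 3.2-fold higher number from compound 1 to compound 4 (0.51 log units; beyond the scatter). An oxygen on the aromatic ring is not enough by itself, as trifluoromethyl in place of benzyl on that oxygen gives a 24-fold lower number from compound 2 to compound 4 (1.38 log units; beyond the scatter), so the group carried by the oxygen matters as well. Nothing available here explains these steps.

The compounds shown leave open whether the fluorines or the oxygen account for the low number of compound 4. A methoxy group, or a trifluoromethyl group directly on the aromatic ring, would separate the two.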